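Dichlorophenyl in place of fluorophenyl on the ring nitrogen

The source may hold more compounds than are shown below. What is called first, only, known or untested is meant among the compounds shown, and "the series" means these compounds.

Compound 1 `Nc1scc(CN2CCN(c3ccc(Cl)c(C(F)(F)F)c3)CC2)c1C(=O)c1ccc(Cl)cc1`: 0%
Compound 2 `Nc1scc(CN2CCN(c3cccc4ccccc34)CC2)c1C(=O)c1ccc(Cl)cc1`: 1%
Compound 3 `Nc1scc(CN2CCN(c3cccc(F)c3)CC2)c1C(=O)c1ccc(Cl)cc1`: 1%

All three compounds were tested in an assay on CHO cells for displacement of a labelled ligand from adenosine receptor A1 (Homo sapiens), read by scintillation counting, with a stated time of 120 min, tested at 10 uM; on this read-out lower numbers stand for less inhibition and higher numbers for more inhibition at the one concentration tested (going by the name of the read-out). In this assay compound 1 gives 0%, compound 2 gives 1% and compound 3 gives 1%. Compound 3 stands level with compound 2, and the remaining step is a number 1 percentage points higher from compound 1 to compound 3 (within the scatter), so the three values cannot be told apart; none of the aryl groups tried so far on the ring nitrogen moves the read-out.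

Compound 4 `Nc1scc(CN2CCN(c3ccc(Cl)c(Cl)c3)CC2)c1C(=O)c1ccc(Cl)cc1` has not yet been measured. Its difference from compound 3 is 3,4-dichlorophenyl in place of 3-fluorophenyl on an amine nitrogen in a ring. Going by the values given here, two measured steps bear on this change, since both alter the same aryl group on the same ring nitrogen: a number 1 percentage points higher from compound 1 to compound 3 (within the scatter), which exchanges a chlorine-bearing phenyl for the fluorophenyl, and no change at the digits printed from compound 2 to compound 3 (within the scatter). Both are flat. A chlorine-bearing phenyl at this position in compound 1 gave no inhibition at all, so compound 4 is expected to behave alike, with an estimated step of a number 1 percentage points higher from compound 3 to compound 4 (within the scatter), that is no step beyond the scatter.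

For compound 4 the estimate in this assay is 2%, with a range from 0% to 12%.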

Compound 4, a percentage reported as inhibition, at one concentration (the size of the read-out at that concentration, not a potency): 1%
The estimate for compound 4 lay 1 percentage points above the measured number, and the stated range covers the measured number.
By their numbers in this assay, from the lowest: compounds 1, 2, 3 and 4 (each within the scatter of the next).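

In this assay, putting 3,4-dichlorophenyl in place of 3-fluorophenyl on the amine nitrogen in a ring shows no change at the digits printed from compound 3 to compound 4 (within the scatter) and putting it in place of naphthalen-1-yl shows no change at the digits printed from compound 2 to compound 4 (within the scatter) so a second chlorine on this phenyl ring adds nothing that can be seen in this read-out. The earlier steps shown here exchanged whole aryl groups, whereas the smaller change of chloro in place of trifluoromethyl on an aromatic carbon shows a number 1 percentage points higher from compound 1 to compound 4 (within the scatter) and so tests a single substituent on that ring, with the same flat outcome. All four aryl groups at this place now give values that cannot be told apart, and nothing available explains this flatness.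

As far as these compounds go, what remains open is whether anything other than an aryl group on this nitrogen, such as a short alkyl chain, a benzyl group or a chain ending in a carboxylic acid, would give inhibition in this assay at all. Equally open, from the compounds shown here alone, is whether changes elsewhere on the shared core, such as replacing the free amine with an amide or the 4-chlorobenzoyl group with an unsubstituted benzoyl group, would lift the read-out clear of these values.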